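A few compounds are considered here, and "the series" means these few. Any claim that something is new, unique, unknown or untested is made for them only; others in the source may bear on it.

Working notes on the series. The shared core is that of compound 1, `Cc1ccc2ccc(-c3cccc(C#N)c3)cc2n1`, which in a functional assay on CHO cells for inhibition of metabotropic glutamate receptor 5 (Rattus norvegicus), read by FLIPR and calcium flux (a lower number here means a stronger inhibitor, a higher number a weaker inhibitor), gives 7.7 nM. Compound 2, `Cc1ccc2ccc(-c3cc(C#N)cc(OC(F)(F)F)c3)cc2n1`, carries trifluoromethoxy on an aromatic carbon, and in this assay compound 2 gives 75 nM. Among the measured compounds shown here, compound 2 thus stands at the highest of the two numbers measured so far, and the only measured step is a 9.7-fold higher number from compound 1 to compound 2 (0.99 log units; beyond the scatter), a modest one. Compound 3, `Cc1ccc2ccc(-c3cc(C#N)cc(OC(C)C)c3)cc2n1`, is not yet measured; its difference from compound 2 reads (isopropyl in place of trifluoromethyl on an oxygen on an aromatic ring). For the measured compounds named here, no measured step exchanges one group for another on that oxygen; the one step touching the same aromatic carbon, a 9.7-fold higher number from compound 1 to compound 2 (0.99 log units; beyond the scatter), concerns trifluoromethoxy in place of hydrogen and so bears on it only indirectly. With the oxygen kept and only the group on it exchanged, the expectation for this assay is a step not beyond the scatter, if anything toward a lower number. The step from compound 2 to compound 3 is estimated at a 1.5-fold lower number from compound 2 to compound 3 (0.18 log units; within the scatter). Compound 3 is therefore expected to give 50 nM, within a range of 15 nM to 200 nM.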

Compound 3, half-maximal inhibitory concentration: 310 nM
For compound 3 the middle estimate is 6.2-fold (0.79 log units) below the measured one; the measured number lies above the stated range.
By their numbers in this assay, from the lowest: compound 1; then compound 2; then compound 3.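

With the oxygen kept on the same aromatic carbon, the group on it is not interchangeable in this assay: isopropyl in place of trifluoromethyl gives a 4.1-fold higher number from compound 2 to compound 3 (0.62 log units; beyond the scatter), so this exchange alone moves the number beyond the scatter. Measured against hydrogen on that aromatic carbon, isopropoxy gives a 40-fold higher number from compound 1 to compound 3 (1.60 log units; beyond the scatter), a larger step than a 9.7-fold higher number from compound 1 to compound 2 (0.99 log units; beyond the scatter), so among the three groups at this position the order from the lowest number is hydrogen, trifluoromethoxy, isopropoxy, and neither group on the oxygen matches hydrogen. No measurement is at hand that would account for the direction or the size of the exchange on the oxygen.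

From the compounds shown here alone, two groups on that oxygen do not define a trend, so it remains open where a methyl or a difluoromethyl on the same oxygen would fall relative to compound 2 and compound 3. Going by these compounds, it is equally open whether a group without that oxygen, such as an amine or a fluorine on the same aromatic carbon, would stay closer to compound 1 than compound 2 does.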